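The compounds below may be only part of what the source reports. "The series", "measured", "known", "first", "only" and "open" are said of these compounds alone.

Compound 1 `Cc1cccc2c1cnn2-c1ccc(NC(=O)Nc2ccc(Cl)c(C(F)(F)F)c2)cc1`; in a functional assay on A549 cells (Homo sapiens) for cytotoxicity, read by MTT assay, with a stated time of 72 h (on this read-out higher numbers stand for weaker inhibition and lower numbers for stronger inhibition), compound 1 gives 5500 nM. Compound 2 `O=C(Nc1ccc(-n2ncc3ccccc32)cc1)Nc1ccc(Cl)c(C(F)(F)F)c1`; in this assay compound 2 gives 9900 nM.

Compound 2 stands at the top of the two numbers, yet the step of a 1.8-fold higher number from compound 1 to compound 2 (0.26 log units; within the scatter) keeps it within the scatter of compound 1. Compound 3 `O=C(Nc1ccc(-n2ncc3cnccc32)cc1)Nc1ccc(Cl)c(C(F)(F)F)c1` differs from compound 2 by a group of 9 heavy atoms (6 carbon, 3 nitrogen; one five-membered aromatic ring with 2 hetero atoms, one six-membered aromatic ring with 1 hetero atom) in place of a group of 9 heavy atoms (7 carbon, 2 nitrogen; one five-membered aromatic ring with 2 hetero atoms, one six-membered aromatic ring of carbon only), on an aromatic carbon. Going by the values given here, no measured step bears on this change; the one step measured concerns methyl against hydrogen elsewhere on the shared core. In this assay the expected step is therefore no change at the digits printed from compound 2 to compound 3 (within the scatter), nothing beyond the scatter. The estimate for compound 3 is 9900 nM, ranging from 3300 nM to 30000 nM.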

Compound 3, half-maximal inhibitory concentration: 3400 nM
For compound 3 the middle estimate is 2.9-fold (0.46 log units) above the measured one, within the range that was stated.
By their numbers in this assay, from the lowest: compounds 3, 1 and 2 (each within the scatter of the next, the first and the last beyond it).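

In this assay, going by these compounds alone, a six-membered aromatic ring with 1 hetero atom in place of one of carbon only gives a 2.9-fold lower number from compound 2 to compound 3 (0.46 log units; beyond the scatter) and is the first change here to reach beyond the scatter, so this part of the group does respond to a swap of one ring atom. Set against the methyl-bearing compound 1, the same group gives a 1.6-fold lower number from compound 1 to compound 3 (0.21 log units; within the scatter) and so stays within the scatter. Nothing available explains the step. On these data alone, what an amine or a methoxy group on this ring would do remains open, as does whether methyl and the ring nitrogen together would go further.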